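The source may hold more compounds than are shown below. What is called first, only, known or untested is meant among the compounds shown, and "the series" means these compounds.

Compound 1, `COC[C@H]1CN(c2ccn(C)c2)C(=O)O1`: in an assay for inhibition of Amine oxidase [flavin-containing] A (Bos taurus), read by fluorescence, with a stated time of 30 min (on this read-out higher numbers stand for weaker inhibition and lower numbers for stronger inhibition), compound 1 gives 300 nM.
Compound 2, `CCn1ccc(N2C[C@H](COC)OC2=O)c1`: in this assay compound 2 gives 0.6 nM.
Compound 3, `CNC[C@H]1CN(c2ccn(C)c2)C(=O)O1`: in this assay compound 3 gives 7 nM.

These three compounds share one core and differ at two places. The change from compound 1 to compound 2 is methyl in place of hydrogen on a saturated chain carbon bound to an aromatic nitrogen and gives a 500-fold lower number from compound 1 to compound 2 (2.70 log units; beyond the scatter). The change from compound 1 to compound 3 is methylamino in place of methoxy on a saturated chain carbon bound to a saturated ring carbon and gives a 43-fold lower number from compound 1 to compound 3 (1.63 log units; beyond the scatter). Compound 3 and compound 2 differ at both places at once; their two values show that compound 2 has the lower number.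

Compound 4, `CCn1ccc(N2C[C@H](CNC)OC2=O)c1`, has not yet been measured in this assay. Going by the values given here, it differs from compound 3 by methyl in place of hydrogen on a saturated chain carbon bound to an aromatic nitrogen, which is the same change as the one from compound 1 to compound 2. The cores of compound 3 and compound 1 differ by methylamino in place of methoxy on a saturated chain carbon bound to a saturated ring carbon, so the change is now made on a core that carries the methylamino group instead of the methoxy group.

If the change repeated its earlier effect in full on compound 3, the number would drop far below that of compound 2. Because the first step was a 500-fold lower number from compound 1 to compound 2 (2.70 log units; beyond the scatter), a large drop is expected, but a somewhat smaller one is estimated here, since a second strong change on an already strong compound often yields less than the first. The expected step from compound 3 to compound 4 is a 140-fold lower number from compound 3 to compound 4 (2.15 log units; beyond the scatter). Compound 4 is therefore estimated at 0.05 nM in this assay, within a range from 0.005 nM to 0.5 nM.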

Compound 4, inhibition constant: 80 nM
Compound 4: the middle estimate sits 1600-fold (3.20 log units) below what was measured, outside the stated range (above it).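

In this assay, going from methyl to ethyl gives an 11-fold higher number from compound 3 to compound 4 (1.06 log units; beyond the scatter), so on the core carrying methylamino this change runs in the opposite direction to its effect on the core carrying methoxy: the same change on two cores in this assay, a 500-fold lower number (2.70 log units; beyond the scatter) from compound 1 to compound 2 and an 11-fold higher number (1.06 log units; beyond the scatter) from compound 3 to compound 4, 5700-fold (3.76 log units) apart, beyond the scatter of two such steps. The same reversal appears when the pairs are read the other way: with ethyl in place, methylamino in place of methoxy gives a 130-fold higher number from compound 2 to compound 4 (2.12 log units; beyond the scatter), whereas with methyl in place it lowered the number: the same change on two cores in this assay, a 43-fold lower number (1.63 log units; beyond the scatter) from compound 1 to compound 3 and a 130-fold higher number (2.12 log units; beyond the scatter) from compound 2 to compound 4, 5700-fold (3.76 log units) apart, beyond the scatter of two such steps. The two changes therefore do not simply add up in these compounds, and what either one does depends on the group at the other place, but these four compounds do not show why this happens or whether it holds on any other core.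

The compounds shown leave open what a longer chain, such as propyl in place of the ethyl group, would do on either core, and what a primary amine or a dimethylamino group would do in place of methylamino. Such compounds would help to show whether the reversal is tied to this one pairing of ethyl and methylamino or extends to related groups.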